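The compounds below may be only part of what the source reports. "The series", "measured", "known", "first", "only" and "open" are said of these compounds alone.

Working notes on the series.

Compound 1 `CC(C)=CCc1cc(C(=O)Nc2cc3ccc(OCC4CCCN(C)C4)c(C)c3oc2=O)ccc1O` is the starting point. For the measured compounds named here, in a functional assay on SK-BR-3 cells (Homo sapiens) for antiproliferative activity (on this read-out lower numbers stand for stronger inhibition and higher numbers for weaker inhibition), compound 1 gives 1300 nM, the highest of the three numbers measured so far. Compound 3 `COC(=O)CNCCCOc1ccc2cc(NC(=O)c3ccc(O)c(CC=C(C)C)c3)c(=O)oc2c1C` gives 1060 nM in this assay, the nearest to it. Compound 2 `CC(C)=CCc1cc(C(=O)Nc2cc3ccc(OCCCNCC(C)C)c(C)c3oc2=O)ccc1O` gives 1030 nM in this assay, the furthest. All three sit within the scatter of one another: a 1.3-fold lower number from compound 1 to compound 2 (0.10 log units; within the scatter), a 1.2-fold lower number from compound 1 to compound 3 (0.09 log units; within the scatter), and a 1.0-fold higher number from compound 2 to compound 3 (0.01 log units; within the scatter).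

Compound 4 `CC(C)=CCc1cc(C(=O)Nc2cc3ccc(OCCCNCc4ccccc4)c(C)c3oc2=O)ccc1O` is not yet measured. Relative to compound 1 the difference is 2-(benzylamino)ethyl in place of 1-methylpiperidin-3-yl on a saturated chain carbon bound to an oxygen on an aromatic ring.

Going by the values given here, two measured steps bear on this change, since both also open the 1-methylpiperidin-3-yl ring into an amine-bearing chain on the same saturated chain carbon bound to an oxygen on an aromatic ring. Both were small: a 1.3-fold lower number from compound 1 to compound 2 (0.10 log units; within the scatter) and a 1.2-fold lower number from compound 1 to compound 3 (0.09 log units; within the scatter). The step between the two chain variants was likewise small: a 1.0-fold higher number from compound 2 to compound 3 (0.01 log units; within the scatter). Nothing in these three compounds suggests that the nature of the group on the amine nitrogen moves the number in this assay beyond the scatter.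

The expected step is therefore a 1.3-fold lower number from compound 1 to compound 4 (0.11 log units; within the scatter), with no movement beyond the scatter. For compound 4 the estimate in this assay is 1000 nM, with a range of 400 nM to 2500 nM.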

Compound 4, half-maximal inhibitory concentration: 470 nM
Estimate against measurement, compound 4: 2.1-fold (0.33 log units) above, within the range that was stated.
By their numbers in this assay, from the lowest: compound 4; then compounds 2, 3 and 1 (each within the scatter of the next).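

In this assay the group on the saturated chain carbon bound to an amine nitrogen now matters: phenyl in place of methoxycarbonyl gives a 2.3-fold lower number from compound 3 to compound 4 (0.35 log units; beyond the scatter) and phenyl in place of isopropyl gives a 2.2-fold lower number from compound 2 to compound 4 (0.34 log units; beyond the scatter) even though those two groups had stayed within the scatter of each other. Opening the 1-methylpiperidin-3-yl ring into an amine-bearing chain does not alone go with a 2.8-fold lower number from compound 1 to compound 4 (0.44 log units; beyond the scatter). Compound 2 and compound 3 also carry such chains yet stay within the scatter of compound 1, which leaves compound 4 as the strongest inhibitor of the four. No measurement among those available accounts for the effect of the phenyl group.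

The compounds shown leave open whether the lower number holds with a longer chain such as 2-phenylethyl on the amine nitrogen, or with a pyridine ring or a fluorine-bearing phenyl in place of phenyl. Also open, from the compounds shown here alone, is whether a benzyl group on the nitrogen of the piperidine ring gives a similar step, which would separate the benzyl group from the opening of the ring.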